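Piperidine nitrogen substituents in a GIP receptor agonist series

The source may hold more compounds than are shown below. What is called first, only, known or untested is meant among the compounds shown, and "the series" means these compounds.

Measured compounds:
- compound 1, `Cc1cnc(N2CCC(c3coc4c(N5CCc6cc(S(C)(=O)=O)ccc65)ncnc34)CC2)nc1`, 159%
- compound 2, `CC(O)c1cnc(N2CCC(c3coc4c(N5CCc6cc(S(C)(=O)=O)ccc65)ncnc34)CC2)nc1`, 33%
- compound 3, `CC(C)(C)OC(=O)N1CCC(c2coc3c(N4CCc5cc(S(C)(=O)=O)ccc54)ncnc23)CC1`, 123%

Read-out throughout is a functional assay on cells for agonist activity at Glucose-dependent insulinotropic receptor (Homo sapiens), read by a luciferase reporter, with a stated time of 4 h; a lower number here means a smaller maximal response, a higher number a larger maximal response. Compound 3 stands second highest of the three numbers; compound 1 lies nearest, a number 36 percentage points lower from compound 1 to compound 3 (beyond the scatter), and compound 2 furthest, a number 90 percentage points higher from compound 2 to compound 3 (beyond the scatter). Compound 1 and compound 2 differ only at the aromatic carbon, a number 126 percentage points lower from compound 1 to compound 2 (beyond the scatter).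

Compound 4, `CS(=O)(=O)c1ccc2c(c1)CCN2c1ncnc2c(C3CCN(c4ncc(F)cn4)CC3)coc12`, is not yet measured. It differs from compound 3 at the amine nitrogen in the ring: 5-fluoropyrimidin-2-yl in place of tert-butoxycarbonyl on an amine nitrogen in a ring

Within the data shown here, two measured steps bear on this change, both exchanging a substituted pyrimidin-2-yl against tert-butoxycarbonyl at the same nitrogen. The 5-methyl analogue sits higher than the carbamate, a number 36 percentage points lower from compound 1 to compound 3 (beyond the scatter), while the 5-(1-hydroxyethyl) analogue sits far lower, a number 90 percentage points higher from compound 2 to compound 3 (beyond the scatter). Among the measured compounds shown here, the direction thus depends on the group at the 5-position, and the data hold no fluorine example. Since compound 1 gives 159% with a small 5-substituent, the step to compound 4 is expected to be upward but modest, a number 17 percentage points higher from compound 3 to compound 4 (beyond the scatter). Compound 4 is therefore estimated at 140%, with a range from 95% to 185% in this assay.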

Compound 4, largest response reached (Emax), in percent of the reference or control that the assay uses: 229%
Estimate against measurement, compound 4: 89 percentage points below, outside the stated range (above it).
By their numbers in this assay, from the lowest: compound 2; then compound 3; then compound 1; then compound 4.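

In this assay, a pyrimidin-2-yl on the amine nitrogen in the ring can exceed tert-butoxycarbonyl by far more than the 5-methyl analogue had shown, with 5-fluoropyrimidin-2-yl in place of the carbamate giving a large rise (a number 106 percentage points higher from compound 3 to compound 4 (beyond the scatter)). The small substituent on the pyrimidine still decides the outcome, since fluoro in place of methyl gives a further large rise (a number 70 percentage points higher from compound 1 to compound 4 (beyond the scatter)) and fluoro in place of 1-hydroxyethyl gives the widest step in the set (a number 196 percentage points higher from compound 2 to compound 4 (beyond the scatter)). The order among these three pyrimidines is thus fluoro, then methyl, then 1-hydroxyethyl, and nothing measured here accounts for it.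

The compounds shown leave open whether this high response is particular to fluoro or would also appear with 5-chloropyrimidin-2-yl, 5-cyanopyrimidin-2-yl or the unsubstituted pyrimidin-2-yl. They also leave open whether the ring nitrogens matter, which a 5-fluoropyridin-2-yl on the same amine nitrogen would test.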